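A few compounds are considered here, and "the series" means these few. Any claim that something is new, unique, unknown or untested is made for them only; others in the source may bear on it.

Of the compounds shown here, two have been measured so far in a functional assay on RAW264.7 cells (Mus musculus) for inhibition, read by Griess assay, with stated times of 1 h and 24 h (on this read-out higher numbers stand for weaker inhibition and lower numbers for stronger inhibition), and only one of them gives a number. Compound 1 `COc1cc(C[C@@H](O)[C@H]2C[C@H](O)[C@@H](c3ccc(O)c(OC)c3)[C@H](c3ccc(O)c(OC)c3)O2)ccc1O` reads > 50000 nM and this is a limit of the assay, not a number. Among the measured compounds shown here, compound 2 `COc1cc(C(=O)C[C@H]2C[C@@H](O)C[C@@H](c3ccc(O)c(OC)c3)O2)ccc1O` reads 17400 nM and so holds the only actual number available in this assay at this stage. Compound 3 `COc1cc(C(=O)C[C@H]2C[C@H](O)C[C@@H](c3ccc(O)c(OC)c3)O2)ccc1O` has the same atoms and bonds as compound 2 and differs only in configuration as drawn. The difference is the two compounds have the same atoms and bonds and differ only in configuration as drawn: 1 of 3 stereo elements differ; a stereocentre at a saturated ring carbon is drawn R in compound 2 and S in compound 3 and nothing leaves or enters: a stereocentre at a saturated ring carbon is drawn R in compound 2 and S in compound 3. For the measured compounds named here, no measured pair shows what such a change does in this assay so the data favour no direction. With compound 2 at 17400 nM as the sole anchor, no shift beyond the usual scatter is expected. The expected step of a 1.1-fold higher number from compound 2 to compound 3 (0.06 log units; within the scatter) is therefore small, though a reading given only as a limit remains possible. Compound 3 is estimated at 20000 nM with an expected range from 7000 nM to 50000 nM in this assay once it is measured.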

Compound 3, half-maximal inhibitory concentration: > 50000 nM
Compound 3: no number, only a limit; the forecaster's own chance of this, stated with the estimate: 25%; middle value at least 2.5-fold (0.39 log units) from the limit.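

In this assay, redrawing one stereocentre at a saturated ring carbon from R to S gives an at least 2.8-fold higher number from compound 2 to compound 3 (0.45 log units; beyond the scatter), the first step available between measured compounds that differ in one place. Compound 3 gives > 50000 nM, which is a limit of the assay and not a number. The step can be put down to configuration alone, because nothing else separates the two structures: the fact that compounds 2 and 3 differ only in the configuration as drawn

From the compounds shown here alone, how large the step really is stays open, because the reading for compound 3 is a limit: the limit of > 50000 nM in this assay, at which 2 of the 3 values shown sit. Also open is whether an amine or a carboxylic acid at this saturated ring carbon, in place of the group that compound 2 carries there, would give a number in this assay, and whether the R drawing would still give a number on a different core.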